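The source may hold more compounds than are shown below. What is called first, only, known or untested is meant among the compounds shown, and "the series" means these compounds.

Compound 1 `CC1=CC[C@H](C(C)(C)NC(=S)N/N=C/c2ccccc2)CC1` is the starting point of this comparison. Among the compounds with values here, in a functional assay on PC-3 cells (Homo sapiens) for inhibition, read by sulforhodamine B assay, with a stated time of 48 h (a higher number here means a weaker inhibitor of growth, a lower number a stronger inhibitor of growth), compound 1 gives 5700 nM, the lowest of the two numbers measured so far; its nearest neighbour, compound 2 `CC1=CC[C@H](C(C)(C)NC(=S)N/N=C/c2cccc(Cl)c2)CC1`, gives 6600 nM, and the separation a 1.2-fold higher number from compound 1 to compound 2 (0.06 log units; within the scatter) lies within the scatter, so the two are not told apart. The compound now awaiting measurement, compound 3 `CC1=CC[C@H](C(C)(C)NC(=S)N/N=C/c2ccc(Cl)cc2)CC1`, differs from compound 1 by chloro in place of hydrogen on an aromatic carbon. Within the data shown here, only one measured step bears on this change, a 1.2-fold higher number from compound 1 to compound 2 (0.06 log units; within the scatter), which also put chloro in place of hydrogen on an aromatic carbon of the same ring and stayed within the scatter. On that basis no movement beyond the scatter is expected for compound 3, whose step from compound 1 is estimated at a 1.1-fold higher number from compound 1 to compound 3 (0.02 log units; within the scatter). Compound 3 is therefore expected to give about 6000 nM, with a likely range from 3000 nM to 12000 nM.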

Compound 3, concentration for total growth inhibition: 1700 nM
Compound 3: middle estimate off by 3.5-fold (0.55 log units), on the high side, and the stated range ends above it.
By their numbers in this assay, from the lowest: compound 3; then compounds 1 and 2 (each within the scatter of the next).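

In this assay, chloro on this aromatic ring does not act the same way at each carbon: para to a large group it gives a 3.4-fold lower number from compound 1 to compound 3 (0.53 log units; beyond the scatter), while the earlier chloro step, a 1.2-fold higher number from compound 1 to compound 2 (0.06 log units; within the scatter), stayed within the scatter. The direct comparison of the two chloro compounds, 4-chlorophenyl in place of 3-chlorophenyl, gives a 3.9-fold lower number from compound 2 to compound 3 (0.59 log units; beyond the scatter), so the position of the chloro group matters here and not merely its presence. Nothing available here accounts for this difference between the two positions.

Going by these compounds, whether bromo, methoxy or an amine at the same place would move the number as chloro does remains open. Also open is whether the step would hold with a different group in place of the rest of the core of compound 1, which all the compounds shown share.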